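From 4-chlorobenzyl to 2,4-difluorobenzyl: compound 3 awaited

A few compounds are considered here, and "the series" means these few. Any claim that something is new, unique, unknown or untested is made for them only; others in the source may bear on it.

Compound 1 `c1ccc(-c2ccc(Cn3cncc3CNc3ccc(-c4nc5ccccc5s4)c(-c4ccccc4)c3)cc2)cc1`: > 1000 nM (a limit)
Compound 2 `Clc1ccc(Cn2cncc2CNc2ccc(-c3nc4ccccc4s3)c(-c3ccccc3)c2)cc1`: > 1000 nM (a limit)

In a toxicity assay on NIH3T3 cells (Mus musculus) for cytotoxicity, read by resazurin assay (on this read-out lower numbers stand for an effect already at smaller amounts and higher numbers for an effect only at larger amounts of compound), compound 2 gives > 1000 nM, which is a limit and not a number. Compound 1 gives > 1000 nM, and this too is a limit. Neither compound therefore has a numerical value, and the data so far come down to the limit of > 1000 nM in this assay, at which 2 of the 2 values shown sit.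

Compound 3 `Fc1ccc(Cn2cncc2CNc2ccc(-c3nc4ccccc4s3)c(-c3ccccc3)c2)c(F)c1` differs from compound 2 in one place, on a saturated chain carbon bound to an aromatic nitrogen: 2,4-difluorophenyl in place of 4-chlorophenyl on a saturated chain carbon bound to an aromatic nitrogen. Cut one bond further out, 4-chlorobenzyl gives way to 2,4-difluorobenzyl.

Among the compounds with values here, the one measured step that bears on this change is a step that the two limits leave unreadable from compound 1 to compound 2, with chloro in place of phenyl on an aromatic carbon. It offers no size to carry over. Since that step is unreadable and compound 2 stands at the limit of > 1000 nM, no step beyond the scatter is expected in this assay, and no direction can be favoured. The estimated step is a step that the limit leaves unreadable from compound 2 to compound 3. Compound 3 is expected at 1500 nM, with an estimated range from 600 nM to 5000 nM, and it may well be reported only as a limit.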

Compound 3, half-maximal effective concentration: > 1000 nM
Compound 3: a limit, no number; the forecaster's own chance of this, stated with the estimate: 75%; the middle value is on the limit's open side.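

In this assay compound 3 gives > 1000 nM, which is a limit and not a number. Within the data shown here, no step can therefore be read among compound 1, compound 2 and compound 3. The compounds shown leave open at what concentration any of them would produce an effect, and whether these changes alter it at all: the limit of > 1000 nM in this assay, at which 3 of the 3 values shown sit.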